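Bromo for hydrogen on a weak adenosine receptor ligand

The compounds below may be only part of what the source reports. "The series", "measured", "known", "first", "only" and "open" are said of these compounds alone.

Two compounds share a core carrying a propyl group. Compound 1 `CCCn1cnc2c(N)nc(NCc3ccccc3)nc21` gives 7600 nM in an assay on CHO cells for displacement of a labelled ligand from adenosine receptor A1 (Homo sapiens) (on this read-out lower numbers stand for stronger inhibition and higher numbers for weaker inhibition), while compound 2 `CCCn1cnc2c(NCc3ccccc3)ncnc21` gives 42800 nM, the higher of the two numbers, a gap that lies beyond the scatter. Compound 3 `CCCn1c(Br)nc2c(NCc3ccccc3)ncnc21` differs from compound 2 by bromo in place of hydrogen on an aromatic carbon. Among the measured compounds shown here, no measured pair shows this change, so the expected step of a 1.4-fold lower number from compound 2 to compound 3 (0.15 log units; within the scatter) is a guess of modest size, without clear direction, and may stay within the scatter. Compound 3 is accordingly estimated at 30000 nM, with a range from 8000 nM to 120000 nM.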

Compound 3, inhibition constant: 5620 nM
Estimate against measurement, compound 3: 5.3-fold (0.73 log units) above, and the stated range ends above it.
By their numbers in this assay, from the lowest: compounds 3 and 1 (each within the scatter of the next); then compound 2.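

In this assay, bromo in place of hydrogen on the aromatic carbon between two ring nitrogen atoms gives a step beyond the scatter (a 7.6-fold lower number from compound 2 to compound 3 (0.88 log units; beyond the scatter)). This position, next to the ring atom that bears a propyl group, therefore accepts a bromine atom and gains inhibition rather than losing it. Nothing measured here accounts for this gain.

Going by these compounds, whether chloro, methyl or a methoxy group on this carbon would do the same stays open. So does whether bromo would give a similar step on the core of compound 1.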